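The compounds below may be only part of what the source reports. "The series", "measured", "known", "first", "only" and "open" are said of these compounds alone.

Working notes on the series. Among the compounds with values here, compound 2 `N#CC1=C(N)N(c2ccc(S(N)(=O)=O)cc2)C2=C(CCCC2)C1c1ccc(Cl)c(Cl)c1` stands highest of the two numbers measured so far in a functional assay on Ehrlich cells (Mus musculus) for cytotoxicity, read by trypan blue exclusion, with a stated time of 2 h, tested at 25 ug/mL; a higher number here means a stronger effect of the compound at the concentration tested, a lower number a weaker effect: in this assay compound 2 gives 40%, while compound 1 `N#CC1=C(N)N(c2ccc(S(N)(=O)=O)cc2)C2=C(CCCC2)C1c1cccc([N+](=O)[O-])c1` gives 1%. Within the data shown here, the step of a number 39 percentage points higher from compound 1 to compound 2 (beyond the scatter) is the only measured step in the set, and it shows that exchanging the group on the saturated ring carbon can move the read-out by a large amount.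

Compound 3 `N#CC1=C(N)N(c2ccc(S(N)(=O)=O)cc2)C2=C(CCCC2)C1c1cccs1` is not yet measured. It differs from compound 2 by thiophen-2-yl in place of 3,4-dichlorophenyl on a saturated ring carbon. Among the measured compounds shown here, no measured step covers this exchange; the step from compound 1 to compound 2 bears on it only in that both change the same position, and that step was large. The direction for compound 3 cannot be read from the data, since neither of the measured compounds carries the entering group. The estimate is therefore placed below compound 2 with a wide range. Compound 3 is expected to give about 20% in this assay, between 2% and 50%, which means an expected step of a number 20 percentage points lower from compound 2 to compound 3 (beyond the scatter).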

Compound 3, a percentage reported as activity, at one concentration (the size of the read-out at that concentration, not a potency): 5%
For compound 3 the middle estimate is 15 percentage points above the measured one; the range from low to high includes it.
By their numbers in this assay, from the lowest: compounds 1 and 3 (each within the scatter of the next); then compound 2.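

In this assay, the exchange of 3,4-dichlorophenyl for thiophen-2-yl gives a number 35 percentage points lower from compound 2 to compound 3 (beyond the scatter) and so shows that a second aromatic group on this saturated ring carbon also falls well short of the 3,4-dichlorophenyl read-out. The exchange of 3-nitrophenyl for thiophen-2-yl gives a number 4 percentage points higher from compound 1 to compound 3 (within the scatter) and so leaves these two groups unseparated here, although one is a five-membered aromatic ring with a hetero atom and the other a six-membered aromatic ring of carbon only. Among the three compounds, the high read-out therefore goes with 3,4-dichlorophenyl alone and not with an aromatic ring at this position as such, and nothing at hand explains why.

The compounds shown leave open whether the two chlorine atoms together are needed, which 4-chlorophenyl, 3-chlorophenyl and plain phenyl on the same carbon would help to separate. They also leave open whether an aromatic ring is needed at all, a question that cyclohexyl or a short alkyl chain at this position would address, and whether 3,4-dichlorophenyl keeps its read-out when the 4-sulfamoylphenyl group on the ring nitrogen is exchanged.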